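Compound 1 to compound 4: swapping the oxolan-3-yl group

The source may report more compounds than this note shows. Statements on the series, on what has been measured and on what is new or still open speak of the compounds shown alone.

Compound 1 `O=C(N/N=C/c1ccc([N+](=O)[O-])cc1)Nc1cc2c(Nc3ccc(F)c(Cl)c3)ncnc2cc1O[C@H]1CCOC1` stands highest of the three numbers in a functional assay on A549 cells (Homo sapiens) for cytotoxicity, read by MTT assay, with a stated time of 72 h (on this read-out higher numbers stand for weaker inhibition and lower numbers for stronger inhibition), at 31200 nM. Compound 2 `O=C(N/N=C/c1ccc(O)c(Br)c1)Nc1cc2c(Nc3ccc(F)c(Cl)c3)ncnc2cc1O[C@H]1CCOC1` gives 4310 nM and compound 3 `O=C(N/N=C/c1ccc(O)cc1)Nc1cc2c(Nc3ccc(F)c(Cl)c3)ncnc2cc1O[C@H]1CCOC1` gives 1320 nM.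

The next structure is compound 4 `COc1cc2ncnc(Nc3ccc(F)c(Cl)c3)c2cc1NC(=O)N/N=C/c1ccc([N+](=O)[O-])cc1`, which differs from compound 1 by methyl in place of oxolan-3-yl on an oxygen on an aromatic ring. The 4-nitrophenyl group stays.

The measured steps are a 7.2-fold lower number from compound 1 to compound 2 (0.86 log units; beyond the scatter), a 24-fold lower number from compound 1 to compound 3 (1.37 log units; beyond the scatter) and a 3.3-fold lower number from compound 2 to compound 3 (0.51 log units; beyond the scatter). All lie beyond the scatter, but all three change the group on the carbon with a double bond to nitrogen. Among the compounds with values here, none touches the oxygen substituent, so they bear on this change only indirectly, and the series holds no measured step at this place. With no evidence for a direction, no shift beyond the scatter is expected in this assay.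

The expected step is a 1.1-fold lower number from compound 1 to compound 4 (0.05 log units; within the scatter). For compound 4 the estimated value is 28000 nM, with an expected range of 10000 nM to 70000 nM.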

Compound 4, half-maximal inhibitory concentration: 35100 nM
Compound 4: middle estimate off by 1.3-fold (0.10 log units), on the low side; the measured number falls inside the stated range.
By their numbers in this assay, from the lowest: compound 3; then compound 2; then compounds 1 and 4 (each within the scatter of the next).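

Methyl in place of oxolan-3-yl on an oxygen on an aromatic ring gives a 1.1-fold higher number from compound 1 to compound 4 (0.05 log units; within the scatter) in this assay, the first step read at this place. With the 4-nitrophenyl group held, this change removes the five-membered ring and its defined stereocentre without a shift beyond the scatter, unlike each of the steps at the carbon with a double bond to nitrogen. Nothing at hand accounts for this result.

On these data alone, compound 1 and compound 4 both carry the 4-nitrophenyl group, so it stays open whether the same swap would also fall within the scatter with the 3-bromo-4-hydroxyphenyl group of compound 2 or the 4-hydroxyphenyl group of compound 3. Also open, as far as these compounds go, is how a longer chain ending in an amine or a carboxylic acid would read on this oxygen.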